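Oxygen for Nitrogen in the Fused Ring of Compound 2

The compounds below may be only part of what the source reports. "The series", "measured", "known", "first", "only" and "open" are said of these compounds alone.

Going by the values given here, compound 2 `CC(=O)N[C@@H]1CCC[C@H](C(=O)Nc2cc(-c3cnn4c3CN(C)CC4)c(Cl)cn2)C1` is the slower-cleared of the two compounds measured so far. In an ADME assay on cells (Hepatocyte, Rattus norvegicus) for metabolic stability, using equilibrium dialysis (a higher number here means faster removal of the compound, a lower number slower removal), compound 2 gives 7.7 uL/min, the lowest of the two numbers, while compound 1 `CC(=O)N[C@@H]1CCC[C@H](C(=O)Nc2cc(-c3cnn4c3CCCC4)c(Cl)cn2)C1` gives 46 uL/min. Among the compounds with values here, the one measured step, a 6.0-fold lower number from compound 1 to compound 2 (0.78 log units; beyond the scatter), comes from changing the six-membered non-aromatic ring that sits on the five-membered aromatic ring.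

Compound 3 `CC(=O)N[C@@H]1CCC[C@H](C(=O)Nc2cc(-c3cnn4c3OCCC4)c(Cl)cn2)C1` alters that same ring once more: a group of 9 heavy atoms (6 carbon, 2 nitrogen, 1 oxygen; one five-membered aromatic ring with 2 hetero atoms, one six-membered non-aromatic ring with 2 hetero atoms) in place of a group of 10 heavy atoms (7 carbon, 3 nitrogen; one five-membered aromatic ring with 2 hetero atoms, one six-membered non-aromatic ring with 2 hetero atoms), on an aromatic carbon. Within the data shown here, no measured step follows this exact change, so the step from compound 1 to compound 2 is the only guide, and it shows only that this ring can move this assay by a modest amount. Since the group entering compound 3 is neither the group found in compound 1 nor the group found in compound 2, a value between those two is expected, and compound 3 is expected to show a 2.6-fold higher number from compound 2 to compound 3 (0.41 log units; beyond the scatter). For compound 3 this assay is estimated at 20 uL/min, with a range from 7 uL/min to 55 uL/min.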

Compound 3, intrinsic clearance in a liver preparation (reported as CLH), per the amount of preparation that the assay uses: 34 uL/min
Estimate against measurement, compound 3: 1.7-fold (0.23 log units) below, and the stated range covers the measured number.
By their numbers in this assay, from the lowest: compound 2; then compounds 3 and 1 (each within the scatter of the next).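

The new step, a 4.4-fold higher number from compound 2 to compound 3 (0.64 log units; beyond the scatter), shows that a ring holding an oxygen does not keep the slower removal seen with compound 2 in this assay, even though the group leaving and the group entering have the same hydrogen-bond counts and the same kinds of ring. The step of a 1.4-fold lower number from compound 1 to compound 3 (0.13 log units; within the scatter) shows that the all-carbon ring of compound 1 and the oxygen ring of compound 3 cannot be told apart in this assay, so among these three compounds only the nitrogen-containing group of compound 2 stands apart, with steps to both others beyond the scatter. No measurement at hand gives a reason for this difference.

Compound 2 differs from compound 3 in several ways at once, including the methyl group on its ring nitrogen and the place of the hetero atom in the ring, so these compounds cannot show which feature matters. As far as these compounds go, it also remains open how this assay would respond to the same ring with a hydrogen, an ethyl group or an acetyl group on that nitrogen, or with an oxygen in the nitrogen's place.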